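The source may hold more compounds than are shown below. What is called first, only, known or untested is meant among the compounds shown, and "the series" means these compounds.

In an ADME assay on HEL cells (Homo sapiens) for cytotoxicity (a lower number here means that less compound is tolerated, a higher number that more compound is tolerated), compound 1 `CCOc1ccc(/C=N/NC(=O)COc2cccc3ccccc23)cc1O` gives 18.1 ug/mL and compound 2 `C/C(=N\NC(=O)COc1cccc2ccccc12)c1cccc([N+](=O)[O-])c1` gives 10.5 ug/mL. These two numbers lie within the usual scatter of each other, so neither compound can be said to stand apart from the other. The next compound, compound 3 `C/C(=N\NC(=O)COc1cccc2ccccc12)c1ccccc1`, is built from compound 2 by one structural change: hydrogen in place of nitro on an aromatic carbon, turning 3-nitrophenyl into phenyl (hydrogen in place of nitro on an aromatic carbon). Going by the values given here, no measured pair here isolates a single change, so the data give no direct guide to the size of this step. With compound 2 at 10.5 ug/mL as the starting point, no shift beyond the scatter is expected in this assay. The expected step is a 1.3-fold higher number from compound 2 to compound 3 (0.12 log units; within the scatter). For compound 3 the estimated value is 14 ug/mL, with an expected range of 6 ug/mL to 35 ug/mL.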

Compound 3, half-maximal cytotoxic concentration: 20 ug/mL
For compound 3 the middle estimate is 1.4-fold (0.15 log units) below the measured one; low and high end bracket the measured number.
By their numbers in this assay, from the lowest: compounds 2, 1 and 3 (each within the scatter of the next).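

In this assay, going by these compounds alone, compound 2 and compound 3 form the first pair that differs in only one place, and swapping nitro for hydrogen on the aromatic carbon gives a 1.9-fold higher number from compound 2 to compound 3 (0.28 log units; within the scatter). Within the data shown here, this pair therefore offers a first direct reading at this position: turning 3-nitrophenyl into phenyl, which removes three heavy atoms, produces no difference that can be told apart from ordinary repeat variation in this assay. Nothing measured here offers an explanation for how these two compounds compare.

From the compounds shown here alone, it remains open whether an amine, a carboxylic acid or a methoxy group at this same ring position would also stay within the scatter of phenyl. Also open, going by these compounds, is whether the same swap from nitro to hydrogen would read the same way at another position on the ring.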